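Swapping an isobutyl for a chloro-fluoro-benzyl arm

A few compounds are considered here, and "the series" means these few. Any claim that something is new, unique, unknown or untested is made for them only; others in the source may bear on it.

Compound 3 `COc1ccc(F)cc1CNCCCNc1ccnc2cc(CC(C)C)ccc12` gives 4200 nM in a physicochemical assay for solubility, with a stated time of 18 h, at pH 7.4; on this read-out higher numbers stand for higher solubility and lower numbers for lower solubility. Compound 2 `COc1ccc(F)cc1CNCCCNc1ccnc2cc(Cc3cc(C)cc(C)c3)ccc12` gives 4200 nM, and compound 1 `COc1ccc(Oc2ccc3c(NCCCNCc4cc(F)ccc4OC)ccnc3c2)cc1` gives 14500 nM; so compound 3 sits level with compound 2 and together they are the lowest of the three. Compound 4 `COc1ccc(F)cc1CNCCCNc1ccnc2cc(Cc3ccc(F)cc3Cl)ccc12` carries 2-chloro-4-fluorophenyl in place of isopropyl on a saturated chain carbon bound to an aromatic carbon. The step that bears most directly on this is no change at the digits printed from compound 2 to compound 3 (within the scatter), where an aromatic ring replaced an alkyl group at the same place without effect; a 3.5-fold lower number from compound 1 to compound 2 (0.54 log units; beyond the scatter) and a 3.5-fold lower number from compound 1 to compound 3 (0.54 log units; beyond the scatter) concern a different position. A step of no more than the scatter is therefore expected, a 1.1-fold lower number from compound 3 to compound 4 (0.02 log units; within the scatter). Compound 4 is estimated at 4000 nM, with a range from 1500 nM to 10000 nM.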

Compound 4, solubility: 4200 nM
Compound 4: middle estimate off by 1.1-fold (0.02 log units), on the low side; low and high end bracket the measured number.
By their numbers in this assay, from the lowest: compounds 2, 3 and 4 (each within the scatter of the next); then compound 1.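

At this place, on a saturated chain carbon bound to an aromatic carbon, this assay does not separate the new 2-chloro-4-fluorophenyl from isopropyl (no change at the digits printed from compound 3 to compound 4 (within the scatter)) or from 3,5-dimethylphenyl (no change at the digits printed from compound 2 to compound 4 (within the scatter)). So a ring carrying chlorine and fluorine reads the same as a ring carrying two methyls, and the same as having no ring at all. The gap to the 4-methoxyphenoxy compound also stays (a 3.5-fold lower number from compound 1 to compound 4 (0.54 log units; beyond the scatter)). Nothing available explains why these groups read alike. As far as these compounds go, whether an amine or a carboxylic acid at this place would shift the number remains open.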